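Phthalazinone series: benzyl to hydroxyethyl at the ring nitrogen

The source may report more compounds than this note shows. Statements on the series, on what has been measured and on what is new or still open speak of the compounds shown alone.

Measured so far:
compound 1, `Oc1nnc(-c2cccnc2)c2ccccc12`, 10200 nM
compound 2, `O=c1c2ccccc2c(-c2cccnc2)nn1Cc1ccccc1`, 2450 nM

Compound 2 gives the lowest of the two numbers recorded in a functional assay (trachea) with Cavia porcellus as the target; on this read-out lower numbers stand for stronger inhibition and higher numbers for weaker inhibition; compound 1 sits at a higher number, and the gap between them lies beyond the usual scatter. Compound 3, `O=c1c2ccccc2c(-c2cccnc2)nn1CCO`, has not yet been measured in this assay. It differs from compound 2 in one place: hydroxymethyl in place of phenyl on a saturated chain carbon bound to an aromatic nitrogen. The only reference for what a substituent on that nitrogen contributes is the pair of compounds 1 and 2, where compound 2 with its benzyl group records the lower number. With hydroxymethyl in place of phenyl the step is expected to run toward a weaker number, a 2.2-fold higher number from compound 2 to compound 3 (0.35 log units; beyond the scatter), though its size is uncertain. Compound 3 is estimated at 5500 nM, with a likely range from 2000 nM to 15000 nM.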

Compound 3, half-maximal inhibitory concentration: 4570 nM
Compound 3: the middle estimate sits 1.2-fold (0.08 log units) above what was measured, and the stated range covers the measured number.
By their numbers in this assay, from the lowest: compounds 2 and 3 (each within the scatter of the next); then compound 1.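

Benzyl to 2-hydroxyethyl gives a 1.9-fold higher number from compound 2 to compound 3 (0.27 log units; within the scatter) in this assay and so compound 2 and compound 3 cannot be told apart on this read-out. On a saturated chain carbon bound to an aromatic nitrogen, the phenyl ring is therefore not needed to stay within the scatter of compound 2: hydroxymethyl, with no ring and with a hydrogen-bond donor and acceptor, serves as well in this one comparison. Nothing measured here bears on why the two groups read alike.

Still open, from the compounds shown here alone, is whether this position stays as flat for groups of other kinds, such as an amine or a carboxylic acid at the end of the chain, or a longer chain. A single step also cannot show how far the tolerance at this nitrogen extends.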